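The source may hold more compounds than are shown below. What is called first, only, known or untested is meant among the compounds shown, and "the series" means these compounds.

Working notes on the series.

Compound 1, `CCOC(=O)c1cnn(-c2nc(-c3ccccc3Cl)c(C#N)c(=O)n2C)c1N`, is the reference point for the step considered here. In a functional assay, with a stated time of 20 min (on this read-out higher numbers stand for weaker inhibition and lower numbers for stronger inhibition), compound 1 gives 78 ug/mL. Among the compounds with values here, the only other measured member is compound 2, `CSc1nc(-c2ccco2)c(C#N)c(=O)n1C`, which in this assay gives 68 ug/mL; the numbers for compound 1 and compound 2 lie within the usual scatter of each other, so nothing separates them on this read-out. Within the data shown here, compound 2 shares the cyano-bearing core but differs from compound 1 in more than one place, so no single-change step can be drawn from it.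

The unmeasured compound 3, `CCOC(=O)c1cnn(-c2nc(-c3cccc(O)c3O)c(C#N)c(=O)n2C)c1N`, differs from compound 1 in one place: 2,3-dihydroxyphenyl in place of 2-chlorophenyl on an aromatic carbon. Among the measured compounds shown here, no measured pair isolates this kind of change, so there is no step to lean on. The expectation for compound 3 is therefore a step of a 1.3-fold lower number from compound 1 to compound 3 (0.11 log units; within the scatter) of no more than the scatter, with no clear direction. Compound 3 is expected to give about 60 ug/mL in this assay, in a range from 25 ug/mL to 150 ug/mL.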

Compound 3, half-maximal inhibitory concentration: 41 ug/mL
For compound 3 the middle estimate is 1.5-fold (0.17 log units) above the measured one, within the range that was stated.
By their numbers in this assay, from the lowest: compounds 3, 2 and 1 (each within the scatter of the next).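

Within the data shown here, the first single-change step at this position, read in this assay, is a 1.9-fold lower number from compound 1 to compound 3 (0.28 log units; within the scatter), with 2,3-dihydroxyphenyl in place of 2-chlorophenyl on an aromatic carbon. The entering group carries hydrogen-bond donors and acceptors that 2-chlorophenyl lacks, and it replaces chlorine with oxygen, yet the two compounds are not separated on this read-out, so this position accepts both groups without a resolved difference in the number. Nothing available bears on why these two groups are not separated.

As far as these compounds go, whether a phenyl with a single hydroxyl, or an aminophenyl or a carboxyphenyl, at this position would give a step beyond the scatter remains open. The compounds shown also leave open whether the 2,3-dihydroxyphenyl step holds on a core carrying a different group in place of the ethyl ester.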